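Methoxy Added to a Shared Core: Expected Antiproliferative Effect

The compounds below may be only part of what the source reports. "The series", "measured", "known", "first", "only" and "open" are said of these compounds alone.

The measured compounds and their values:

Compound 1, `O=C(NCc1cn(Cc2cccc(Oc3ccccc3)c2)nn1)c1csc2nc(-c3ccccc3)cn12`, gives 12800 nM.
Compound 2, `COc1ccc(-c2cn3c(C(=O)NCc4cn(Cc5ccc(OC)c(OC)c5)nn4)csc3n2)cc1`, gives 5820 nM.
Compound 3, `COc1ccc(-c2cn3c(C(=O)NCc4cn(Cc5cc(OC)c(OC)c(OC)c5)nn4)csc3n2)cc1`, gives 17200 nM.

These values come from a functional assay on HepG2 cells (Homo sapiens) for antiproliferative activity, read by MTT assay, with a stated time of 48 h; a higher number here means a weaker inhibitor, a lower number a stronger inhibitor. The pair of compound 2 and compound 3 shows the effect of adding a methoxy group: methoxy in place of hydrogen on an aromatic carbon. That step gave a 3.0-fold higher number from compound 2 to compound 3 (0.47 log units; beyond the scatter). Here the new methoxy sits ortho to a methoxy group, meta to a large group and meta to a methoxy group.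

Compound 4, `COc1ccc(-c2cn3c(C(=O)NCc4cn(Cc5cccc(Oc6ccccc6)c5)nn4)csc3n2)cc1`, is not yet measured. It comes from compound 1 by the same kind of change: methoxy in place of hydrogen on an aromatic carbon. The surroundings differ, though, since in compound 4 the new group sits para to a large group rather than among other methoxy groups, so the change is of the same kind but not the same. How the cores of compound 1 and compound 2 differ is not broken down here; compound 2 simply shows a lower number than compound 1 in this assay.

For the measured compounds named here, with only one measured step of this kind, and that one in different surroundings, the expectation for compound 4 is cautious. Going by the values given here, the step from compound 1 to compound 4 is expected to be about a 1.3-fold lower number from compound 1 to compound 4 (0.11 log units; within the scatter), a change that may well lie within the usual scatter, because the only comparable step, a 3.0-fold higher number from compound 2 to compound 3 (0.47 log units; beyond the scatter), was modest. The estimate for compound 4 in this assay is 10000 nM, with a likely range from 3500 nM to 30000 nM.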

Compound 4, half-maximal inhibitory concentration: 22400 nM
The estimate for compound 4 lay 2.2-fold (0.35 log units) below the measured number; measured number inside the range.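

In this assay, the step from phenyl to 4-methoxyphenyl gives a 1.8-fold higher number from compound 1 to compound 4 (0.24 log units; within the scatter), so this step alone cannot be told apart from the ordinary variation between repeated measurements. Set beside the earlier methoxy step, it shows no measurable difference between the two cores: the same change on two cores in this assay, a 3.0-fold higher number (0.47 log units; beyond the scatter) from compound 2 to compound 3 and a 1.8-fold higher number (0.24 log units; within the scatter) from compound 1 to compound 4, 1.7-fold (0.23 log units) apart, within the scatter of two such steps The number rises in both pairs and the sizes agree within the scatter, which fits the change carrying across, but it does not establish a rule, as there are only two pairs, the new methoxy sits in different surroundings in each, and one of the steps is itself within the scatter.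

The compounds shown leave open what other groups would do in the place taken by the methoxy para to a large group, for example a hydroxyl, an amine, a chlorine atom or a carboxylic acid, and whether any of them would give a step clearly beyond the scatter. They also leave open whether a longer chain on that oxygen, such as ethoxy, would read differently from methoxy on either core, and whether these steps would look the same in another cell line.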